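Swapping the pyrrole for a saturated oxolane ring

The compounds below may be only part of what the source reports. "The series", "measured", "known", "first", "only" and "open" are said of these compounds alone.

Measured so far:
compound 1 `O=C(Nc1ccc(OC(F)(F)F)cc1)NC1CCN(C(=O)C2CCCOC2)CC1` — 3.42
compound 2 `O=C(Nc1ccc(C(F)(F)F)cc1)NC1CCN(C(=O)C2CCOC2)CC1` — 3.16
compound 3 `O=C(Nc1ccc(OC(F)(F)F)cc1)NC1CCN(C(=O)c2cc[nH]c2)CC1` — 3.34

All three compounds share the same core; they differ in the ring attached to the carbonyl carbon and in the group on the aromatic ring. In a physicochemical assay for lipophilicity, read by HPLC, with a stated time of 90 min, tested at 100 uM (a higher number here means a more lipophilic compound, a lower number a more polar compound), compound 3 gives 3.34. Among the three numbers it is the second highest, and both of its neighbours lie within the scatter: compound 1 stands a little higher, compound 2 a little lower, so no real order between them can be read from these values.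

Compound 4 is `O=C(Nc1ccc(OC(F)(F)F)cc1)NC1CCN(C(=O)C2CCOC2)CC1`, not yet measured. Its change from compound 3 is oxolan-3-yl in place of 1H-pyrrol-3-yl on a carbonyl carbon.

Among the measured compounds shown here, one measured step bears on this: a number 0.08 log units lower from compound 1 to compound 3 (within the scatter). Exchanging the saturated oxane ring for the aromatic pyrrole ring left the number within the scatter. The reverse kind of exchange, aromatic to saturated ring, is now made with a ring of the same size. Compound 2, which already carries oxolan-3-yl, gives a value within the scatter of compound 3, though it differs in a second place as well. Taken together, a step of a number 0.04 log units lower from compound 3 to compound 4 (within the scatter) is expected, which is none beyond the scatter. Compound 4 is therefore estimated at 3.3, in the range 3 to 3.6.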

Compound 4, partition coefficient: 3.22
Beside the measured number, compound 4's estimate is 0.08 log units above it; measured number inside the range.
By their numbers in this assay, from the lowest: compounds 2, 4, 3 and 1 (each within the scatter of the next).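

In this assay the exchange of 1H-pyrrol-3-yl, which carries a hydrogen-bond donor, for oxolan-3-yl, which carries a hydrogen-bond acceptor, on a carbonyl carbon gives a number 0.12 log units lower from compound 3 to compound 4 (within the scatter) and so shows that an aromatic and a non-aromatic ring of five members can be exchanged here without a step beyond the scatter. Among the compounds shown here, the ring size at this place can be read as well, since oxolan-3-yl in place of oxan-3-yl gives a number 0.20 log units lower from compound 1 to compound 4 (within the scatter) and the group on the aromatic carbon can now be read alone for the first time, since trifluoromethoxy in place of trifluoromethyl gives a number 0.06 log units higher from compound 2 to compound 4 (within the scatter) with everything else in the two compounds the same. No measurement is available that could explain why any of these steps has the size it has.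

The compounds shown leave open whether a ring carrying an amine or a carboxylic acid, or an open longer chain in place of a ring, would also stay within the scatter on this carbonyl carbon. They also leave open what a nitrile or a chlorine on the aromatic carbon would give in place of trifluoromethoxy.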